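The compounds below may be only part of what the source reports. "The series", "measured", "known", "first", "only" and "open" are said of these compounds alone.

Measured compounds:
Compound 1, `CCCCCC#Cc1cn(CCC(COC(C)=O)COC(C)=O)c(=O)n(C(=O)c2ccccc2)c1=O`, in a functional assay on MCF7 cells (Homo sapiens) for antiproliferative activity, read by MTT assay, with a stated time of 72 h (on this read-out lower numbers stand for stronger inhibition and higher numbers for weaker inhibition), gives 62200 nM.
Compound 2, `CC(=O)OCC(CCn1cc(C#CCCCCl)c(=O)n(C(=O)c2ccccc2)c1=O)COC(C)=O`, in this assay gives 21000 nM.
Compound 3, `O=c1[nH]c(=O)n(CCC(CO)CO)cc1C#CCc1ccccc1`, in this assay gives only a limit, > 100000 nM.

Compound 3 thus stands at the weak end of the set: its result is a limit of the assay and not a number, and the limit of > 100000 nM in this assay, at which 1 of the 3 values shown sits, shows one of the three values sitting there. Among the compounds with values here, compound 2 is the only measured compound that gives a number well inside the range, and compound 1 lies between.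

Compound 4, `O=c1[nH]c(=O)n(CCC(CO)CO)cc1C#CCCCCl`, differs from compound 3 in one place: 2-chloroethyl in place of phenyl on a saturated chain carbon bound to a triple-bonded carbon. Within the data shown here, the only measured step that bears on this kind of change is a 3.0-fold lower number from compound 1 to compound 2 (0.47 log units; beyond the scatter), where a chloro-bearing chain end gave a modest improvement within an otherwise identical core. Among the measured compounds shown here, that step is not the same change as the one from compound 3 to compound 4, since here a phenyl leaves and a 2-chloroethyl enters, but it points in the same direction, toward a chloro-terminated chain. Compound 3 offers no number to build on, so the step is expected to be a modest gain at most, and it may well leave compound 4 at the limit.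

The expected value for compound 4 in this assay is 60000 nM, within 15000 nM to 200000 nM.
Against the limit of compound 3 this is estimated as an at least 1.6-fold lower number from compound 3 to compound 4 (0.22 log units; that floor lies within the scatter).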

Compound 4, half-maximal inhibitory concentration: 35200 nM
Beside the measured number, compound 4's estimate is 1.7-fold (0.23 log units) above it; the range from low to high includes it.
By their numbers in this assay, from the lowest: compounds 2, 4 and 1 (each within the scatter of the next, the first and the last beyond it). At a limit, above all of these: compound 3.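

In this assay, the change from phenyl to 2-chloroethyl gives an at least 2.8-fold lower number from compound 3 to compound 4 (0.45 log units; beyond the scatter), which shows that on the core with free hydroxyl groups this position can take the read-out from a limit to a number. Compound 3 remains a limit of the assay, so this step gives only a floor for the size of the change: the limit of > 100000 nM in this assay, at which 1 of the 4 values shown sits. A chloro-bearing chain end now goes with a lower number on two different cores, alongside a 3.0-fold lower number from compound 1 to compound 2 (0.47 log units; beyond the scatter) on the core with acetate and benzoyl groups, and no compound shown goes against this, although phenyl leaves in one step and ethyl in the other.

The compounds shown leave open whether the gain comes with the chlorine or with the loss of the phenyl ring, as a plain alkyl chain, an amine or a hydroxyl group in place of the chlorine of compound 4 would tell. They also leave open how far the chain length matters, which a longer chain ending in chlorine on the core of compound 4 would address.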